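Moving the nitrile on the cyanophenyl group

This account rests on a few compounds, and the source may have more. Where it says the series, first, only, none or still open, it means among the compounds named here.

In a functional assay on SH-SY5Y cells (Homo sapiens) for antiproliferative activity, read by MTT assay, with a stated time of 72 h (on this read-out lower numbers stand for stronger inhibition and higher numbers for weaker inhibition), the measured compounds are these
Compound 1 `COc1cc2c(Nc3ccc(C#N)cc3)ncnc2cc1OCCCN1CCC(O)CC1` gives > 100000 nM
Compound 2 `COc1cc2c(Nc3ccc(C#N)cc3)ncnc2cc1OCCCN1CCC(N(C)C)CC1` gives 24300 nM
Compound 3 `COc1cc2c(Nc3ccc(C#N)cc3)ncnc2cc1OCCCN1CCN(C)CC1` gives 13000 nM

The entry for compound 1 is a limit of the assay and not a number. Compound 3 stands level with compound 2, since the step of a 1.9-fold lower number from compound 2 to compound 3 (0.27 log units; within the scatter) lies within the scatter. The two steps out of the limit are larger: an at least 4.1-fold lower number from compound 1 to compound 2 (0.61 log units; beyond the scatter) and an at least 7.6-fold lower number from compound 1 to compound 3 (0.88 log units; beyond the scatter) both lie beyond the scatter.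

Compound 4 `COc1cc2c(Nc3cccc(C#N)c3)ncnc2cc1OCCCN1CCN(C)CC1` differs from compound 3 in one place, and the change is 3-cyanophenyl in place of 4-cyanophenyl on a nitrogen on an aromatic ring in which 3-cyanophenyl stands in place of 4-cyanophenyl on a nitrogen on an aromatic ring. The two have the same atoms, joined differently.

Within the data shown here, none of the measured steps bears directly on this change. All three alter the saturated ring on the chain, while the 4-cyanophenyl group stays the same, so they give no size for it. That leaves compound 3 at 13000 nM as the only anchor in this assay and no direction can be argued. The expected result is a 1.2-fold higher number from compound 3 to compound 4 (0.06 log units; within the scatter) and no clear shift beyond the scatter is expected. For compound 4 the estimate is 15000 nM with an expected range from 5000 nM to 45000 nM as a wide allowance.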

Compound 4, half-maximal inhibitory concentration: 6890 nM
The estimate for compound 4 lay 2.2-fold (0.34 log units) above the measured number, within the range that was stated.
By their numbers in this assay, from the lowest: compounds 4, 3 and 2 (each within the scatter of the next, the first and the last beyond it). At a limit, above all of these: compound 1.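

Among these compounds, compound 4 provides the only step here that touches the aromatic group on the nitrogen, since compounds 1, 2 and 3 all carry 4-cyanophenyl and differ only in the saturated ring on the chain. In this assay, putting 3-cyanophenyl in place of 4-cyanophenyl gives a 1.9-fold lower number from compound 3 to compound 4 (0.28 log units; within the scatter), so with the 4-methylpiperazin-1-yl group on the chain, the two placements of the nitrile cannot be told apart, even though the swap rearranges atoms without adding or removing any. Nothing among the measurements shown bears on the result or offers a reason for it.

The compounds shown leave open whether the same swap would also make no clear difference with 4-(dimethylamino)piperidin-1-yl or 4-hydroxypiperidin-1-yl on the chain, since the nitrile has been moved only with 4-methylpiperazin-1-yl there. They also leave open whether the nitrile itself matters at all, which a plain phenyl group, a chlorine atom or a carboxylic acid in its place on the same ring would begin to answer.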